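Swapping Methoxy for Trifluoromethyl in a Platelet Inhibitor Series

The source may report more compounds than this note shows. Statements on the series, on what has been measured and on what is new or still open speak of the compounds shown alone.

Compound 1 `COc1ccc(C(=O)N(CCN2CCC(OCC(=O)O)CC2)c2ccc(C)cc2)cc1` is measured in a functional assay on a cell-free system (Platelet, plasma, Homo sapiens) for inhibition (a higher number here means a weaker inhibitor, a lower number a stronger inhibitor), where compound 1 gives 1200 nM. Compound 2 `Cc1ccc(N(CCN2CCC(OCC(=O)O)CC2)C(=O)c2ccc(C(F)(F)F)cc2)cc1` carries the change (trifluoromethyl in place of methoxy on an aromatic carbon). In this assay compound 2 reaches > 10000 nM, which is a limit of the assay rather than a number. That change made an at least 8.3-fold higher number from compound 1 to compound 2 (0.92 log units; beyond the scatter); because one value is the limit (the limit of > 10000 nM in this assay, at which 1 of the 3 values shown sits), the true size of this step is not pinned down. Compound 3 `COc1cccc(C(=O)N(CCN2CCC(OCC(=O)O)CC2)c2ccc(Cl)cc2)c1` gives 74 nM in this assay, the lowest of the two numbers. The difference between the cores of compound 1 and compound 3 is not broken down here. Compound 4 `O=C(O)COC1CCN(CCN(C(=O)c2cccc(C(F)(F)F)c2)c2ccc(Cl)cc2)CC1` has not yet been measured; it differs from compound 3 by trifluoromethyl in place of methoxy on an aromatic carbon, where the new group sits meta to a large group rather than para to a large group, so this is the same kind of change as from compound 1 to compound 2, not the same one. Resting on the measured step of an at least 8.3-fold higher number from compound 1 to compound 2 (0.92 log units; beyond the scatter), the expected step is a 6.8-fold higher number from compound 3 to compound 4 (0.83 log units; beyond the scatter). Compound 4 is estimated at 500 nM, between 100 nM and 3000 nM.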

Compound 4, half-maximal inhibitory concentration: > 10000 nM
Compound 4 gave a limit, no number; the forecaster's own chance of this, stated with the estimate: 5%; middle value at least 20-fold (1.30 log units) away from the limit.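

In this assay, trifluoromethyl in place of methoxy gives a weaker inhibitor on both cores, and on the second core the change gives an at least 130-fold higher number from compound 3 to compound 4 (2.13 log units; beyond the scatter). Compound 4 gives > 10000 nM, which is a limit of the assay and not a number. The direction of the change therefore carries over from one core to the other in these two pairs, but its size does not transfer in any measurable way, and it cannot be said whether one core is more sensitive than the other: the same change on two cores in this assay, an at least 8.3-fold higher number (0.92 log units; beyond the scatter) from compound 1 to compound 2 and an at least 130-fold higher number (2.13 log units; beyond the scatter) from compound 3 to compound 4; the limit leaves it open whether they differ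

Still open, as far as these compounds go, is how much activity, if any, compound 2 and compound 4 keep, and whether the loss is specific to trifluoromethyl; a nitrile or an amine at the same place on the ring would help to test this. Also open is which of the differences between the cores of compound 1 and compound 3 accounts for the gap between their values.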